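The source may hold more compounds than are shown below. What is called first, only, known or untested is meant among the compounds shown, and "the series" means these compounds.

In a functional assay on HCT-116 cells (Homo sapiens) for antiproliferative activity, read by MTT assay, with a stated time of 72 h (a higher number here means a weaker inhibitor, a lower number a stronger inhibitor), the measured compounds stand as follows:
compound 1 `CC(=O)N(C)c1ccc2[nH]c(-c3n[nH]c4ccccc34)cc2n1`: 14800 nM
compound 2 `CN(C(=O)C(C)(C)C)c1ccc2[nH]c(-c3n[nH]c4ccccc34)cc2n1`: 18000 nM
compound 3 `CN(C(=O)c1ccc(F)cc1)c1ccc2[nH]c(-c3n[nH]c4ccccc34)cc2n1`: 9270 nM

On these numbers compound 3 sits at the low end of the three, though not beyond the scatter: a 1.6-fold lower number from compound 1 to compound 3 (0.20 log units; within the scatter) and a 1.9-fold lower number from compound 2 to compound 3 (0.29 log units; within the scatter), and likewise a 1.2-fold higher number from compound 1 to compound 2 (0.09 log units; within the scatter). Compound 4 `CN(C(=O)c1ccc(Br)cc1)c1ccc2[nH]c(-c3n[nH]c4ccccc34)cc2n1` differs from compound 3 by bromo in place of fluoro on an aromatic carbon. For the measured compounds named here, no measured step swaps one halogen for another; the three steps available all exchange the whole group on the carbonyl carbon and none moves the number beyond the scatter. Compound 4 is therefore expected to sit near compound 3, with a 1.1-fold lower number from compound 3 to compound 4 (0.04 log units; within the scatter) being the estimated step and no direction beyond the scatter. The estimate for compound 4 in this assay is 8500 nM, ranging from 3000 nM to 25000 nM.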

Compound 4, half-maximal inhibitory concentration: 6110 nM
Beside the measured number, compound 4's estimate is 1.4-fold (0.14 log units) above it; measured number inside the range.
By their numbers in this assay, from the lowest: compounds 4, 3, 1 and 2 (each within the scatter of the next, the first and the last beyond it).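

In this assay, for the compounds shown here, the first halogen exchange in this set, on an aromatic carbon para to a large group, gives a 1.5-fold lower number from compound 3 to compound 4 (0.18 log units; within the scatter) and so stays within the scatter. Even so, 4-bromophenyl on the carbonyl carbon opens the first gaps beyond the scatter here, both modest, with a 2.9-fold lower number from compound 2 to compound 4 (0.47 log units; beyond the scatter) and with a 2.4-fold lower number from compound 1 to compound 4 (0.38 log units; beyond the scatter) to set beside the steps of 4-fluorophenyl, which stayed within it. No evidence here bears on this result. Open, as far as these compounds go, is how chloro, iodo, methoxy or an amine in place of the bromo would read in this assay on the same ring.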